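The compounds below may be only part of what the source reports. "The series", "measured", "known", "first", "only" and "open" are said of these compounds alone.

Measured compounds and their values:

- Compound 1, `CN(C)c1ccc(C(=O)N(CCC(=O)NCc2ccc(Cl)cc2)Cc2ccc(C(=O)NO)cc2)cc1`: 390 nM
- Compound 2, `O=C(CCN(Cc1ccc(C(=O)NO)cc1)C(=O)c1ccccc1)NCc1ccccc1`: 3310 nM
- Compound 3, `Cc1ccc(C(=O)N(CCC(=O)NCc2ccccc2)Cc2ccc(C(=O)NO)cc2)cc1`: 910 nM

The three compounds were tested in a functional assay on SK-N-AS cells (Homo sapiens) for antiproliferative activity, with a stated time of 72 h; a lower number here means a stronger inhibitor, a higher number a weaker inhibitor. Compound 1 gives 390 nM and stands lowest of the three; compound 3 is nearest with 910 nM, and compound 2 is furthest with 3310 nM. All three share one core, differing only in a single group on the outer ring of the benzylamide.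

Compound 4, `Cc1ccc(CNC(=O)CCN(Cc2ccc(C(=O)NO)cc2)C(=O)c2ccc(N(C)C)cc2)cc1`, is not yet measured. It differs from compound 1 by methyl in place of chloro on an aromatic carbon.

For the measured compounds named here, only one measured step touches this position: a 3.6-fold lower number from compound 2 to compound 3 (0.56 log units; beyond the scatter). That step compares methyl with hydrogen, not methyl with chloro, so it bears on the change only indirectly. Both compound 1, carrying chloro, and compound 3, carrying methyl, sit well below compound 2, which carries hydrogen. A swap of chloro for methyl is therefore expected to give little movement, within or near the scatter. Compound 4 is estimated at 450 nM, with a likely range from 200 nM to 1000 nM, which means an expected 1.2-fold higher number from compound 1 to compound 4 (0.06 log units; within the scatter).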

Compound 4, half-maximal inhibitory concentration: 340 nM
Compound 4: middle estimate off by 1.3-fold (0.12 log units), on the high side; the measured number falls inside the stated range.
By their numbers in this assay, from the lowest: compounds 4 and 1 (each within the scatter of the next); then compound 3; then compound 2.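

In this assay, replacing the chloro of the 4-chlorobenzyl group with the methyl of the 4-methylbenzyl group gives a 1.1-fold lower number from compound 1 to compound 4 (0.06 log units; within the scatter) and so leaves the number effectively unchanged. For the compounds shown here, this is the first direct comparison of these two groups at this place on the ring, as no earlier pair set chloro against methyl, and on this reading the two cannot be told apart. No measurement at hand gives a reason for this result.

Still open, on these data alone, is how a different group would read at the same place, such as a methoxy group or an amine. Also open, as far as these compounds go, is how a plain benzyl group, with hydrogen at this place, would compare on the core of compound 1.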